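Side-chain swap from compound 2 to compound 3

The source may report more compounds than this note shows. Statements on the series, on what has been measured and on what is new or still open speak of the compounds shown alone.

Measured in a functional assay on NALM-6 cells (Homo sapiens) for cytotoxicity, with a stated time of 72 h; a higher number here means that more compound is needed for the effect, a lower number that less compound is needed:
- Compound 1 `C=C[C@@](C)(/C=C/c1ccc(O)c(/C=C/C(=O)OCC)c1)CCC=C(C)C` gives 20900 nM
- Compound 2 `C=C[C@@](C)(/C=C/c1ccc(O)c(/C=C/c2ccc(Cl)c(Cl)c2)c1)CCC=C(C)C` gives 7510 nM

Compound 2 holds the lower of the two numbers. Compound 3 `C=C[C@@](C)(/C=C/c1ccc(O)c(/C=C/C=C/c2ccccc2)c1)CCC=C(C)C` carries 2-phenylethenyl in place of 3,4-dichlorophenyl on a double-bonded chain carbon bound to a double-bonded chain carbon. For the measured compounds named here, the only measured step at this place is modest (a 2.8-fold lower number from compound 1 to compound 2 (0.44 log units; beyond the scatter)) and involves a different swap, so no clear direction is expected in this assay and any change should be no larger. The estimated step lies within the scatter (a 1.1-fold higher number from compound 2 to compound 3 (0.03 log units; within the scatter)). For compound 3 the expected value is 8000 nM with an estimated range from 3500 nM to 18000 nM in this assay.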

Compound 3, half-maximal effective concentration: > 43400 nM
Compound 3: only a limit was reported; the forecaster's own chance of this, stated with the estimate: 10%; middle value at least 5.4-fold (0.73 log units) away from the limit.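

In this assay compound 3 gives only a limit, > 43400 nM. On a double-bonded chain carbon bound to a double-bonded chain carbon, the swap from 3,4-dichlorophenyl to 2-phenylethenyl, which both hold one six-membered aromatic ring of carbon only, is not neutral: it gives an at least 5.7-fold higher number from compound 2 to compound 3 (0.76 log units; beyond the scatter). Replacing ethoxycarbonyl with 2-phenylethenyl likewise gives an at least 2.0-fold higher number from compound 1 to compound 3 (0.31 log units; beyond the scatter).

The swap adds a double bond and removes both chlorines at once, and these compounds do not separate the two changes. From the compounds shown here alone, how an amine or a carboxylic acid at this place would behave stays open.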